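Working notes: heteroaryl swap on the sulfur of compound 2

This account rests on a few compounds, and the source may have more. Where it says the series, first, only, none or still open, it means among the compounds named here.

The three measured compounds share one core and differ only on the aromatic ring that carries bromo, methyl or hydrogen. In a functional assay on C6 cells (Rattus norvegicus) for cytotoxicity, read by MTT assay, with a stated time of 24 h, tested at 100 ug/mL (a lower number here means a stronger effect, a higher number a weaker effect of the compound at the concentration tested), compound 1 `O=C(CSc1nnnn1-c1ccccc1)N/N=c1/scc(-c2ccc(Br)cc2)n1-c1ccccc1` gives 24.3%, compound 2 `Cc1ccc(-c2cs/c(=N/NC(=O)CSc3nnnn3-c3ccccc3)n2-c2ccccc2)cc1` gives 28.5%, and compound 3 `O=C(CSc1nnnn1-c1ccccc1)N/N=c1/scc(-c2ccccc2)n1-c1ccccc1` gives 35.8%. Compound 2 sits close to both others: the step of a number 4.2 percentage points higher from compound 1 to compound 2 (within the scatter) and the step of a number 7.3 percentage points higher from compound 2 to compound 3 (within the scatter) are each within the scatter, so no order among compound 1, compound 2 and compound 3 can be read from compound 2's position. Among the measured compounds shown here, the only step beyond the scatter is a number 11.5 percentage points higher from compound 1 to compound 3 (beyond the scatter), a modest one.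

Compound 4 `Cc1ccc(-c2cs/c(=N/NC(=O)CSc3nnc(C)s3)n2-c2ccccc2)cc1` keeps the methyl-bearing ring of compound 2 and changes the other end: 5-methyl-1,3,4-thiadiazol-2-yl in place of 1-phenyl-1H-tetrazol-5-yl on a sulfur. For the measured compounds named here, none of the measured steps touches this part of the molecule; all three concern the aromatic ring, so there is no direct guide for this change. The whole series spans a narrow band in this assay, and the expectation for compound 4 therefore rests on that band alone.

For compound 4 the estimate is 31%, with a range from 18% to 46%, which is an expected step of a number 2.5 percentage points higher from compound 2 to compound 4 (within the scatter), not beyond the scatter.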

Compound 4, a percentage reported as activity, at one concentration (the size of the read-out at that concentration, not a potency): 31.5%
The estimate for compound 4 lay 0.5 percentage points below the measured number; the range from low to high includes it.
By their numbers in this assay, from the lowest: compounds 1, 2, 4 and 3 (each within the scatter of the next, the first and the last beyond it).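

Notes on the sulfur end: in this assay the swap to 5-methyl-1,3,4-thiadiazol-2-yl in place of 1-phenyl-1H-tetrazol-5-yl gives a number 3 percentage points higher from compound 2 to compound 4 (within the scatter) and is the first look at this end of the molecule, as all earlier steps concern the aromatic ring that carries bromo, methyl or hydrogen. The entering group has fewer heavy atoms than the leaving one and has no six-membered aromatic ring, yet the read-outs of the two compounds cannot be told apart, so in this single pair the phenyl-bearing tetrazole is not required to keep the read-out within this band at the one concentration tested. Among the compounds shown here, nothing available accounts for this result, and it rests on the one pair alone.

On these data alone, it remains open whether the same swap stays within the scatter when the aromatic ring carries bromo or hydrogen instead of methyl. As far as these compounds go, it is also open how the read-out responds on this sulfur to a group of a different kind, such as a carboxylic acid or an amine on a longer chain in place of the heteroaryl ring.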